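The source may hold more compounds than are shown below. What is called first, only, known or untested is meant among the compounds shown, and "the series" means these compounds.

Compound 1 `COc1cccc(C(=O)Oc2cc3c(cc2C)[C@@H](C(C)C)CC=C3C)c1`: 11.9% in a functional assay on MCF7 cells (Homo sapiens) for antiproliferative activity, read by sulforhodamine B assay, with a stated time of 48 h, tested at 50 uM; on this read-out lower numbers stand for less inhibition and higher numbers for more inhibition at the one concentration tested (going by the name of the read-out)
Compound 2 `CC1=CC[C@H](C(C)C)c2cc(C)c(OC(=O)c3ccc(C)cc3)cc21`: 65% in this assay

Within the data shown here, compound 1 stands lowest of the two numbers measured so far in this assay; its nearest neighbour is compound 2, and the step of a number 53.1 percentage points higher from compound 1 to compound 2 (beyond the scatter) is large and beyond the scatter. Compound 3 `CC1=CC[C@H](C(C)C)c2cc(C)c(OC(=O)c3cccc(C(F)(F)F)c3)cc21` differs from compound 1 by trifluoromethyl in place of methoxy on an aromatic carbon, the new group sitting on an aromatic carbon of a six-membered aromatic ring of carbon only, meta to a large group. Among the measured compounds shown here, only one measured step bears on this change, and only loosely: from compound 1 to compound 2 the whole aryl group on the carbonyl carbon was exchanged, with a large rise. That shows the number can move far when the ester aryl group is altered, but the present change is a different one, and nothing measured speaks to trifluoromethyl directly. Compound 3 is therefore expected to lie above compound 1, by a moderate step of a number 23.1 percentage points higher from compound 1 to compound 3 (beyond the scatter), with wide uncertainty. The estimate for compound 3 is 35%, within 10% to 65%.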

Compound 3, a percentage reported as inhibition, at one concentration (the size of the read-out at that concentration, not a potency): 86%
Estimate against measurement, compound 3: 51 percentage points below; the whole stated range lies below it.
By their numbers in this assay, from the lowest: compound 1; then compound 2; then compound 3.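

In this assay, trifluoromethyl in place of methoxy on an aromatic carbon brings a number 74.1 percentage points higher from compound 1 to compound 3 (beyond the scatter), while the rest of the structure stays the same. The earlier step exchanged the whole aryl group on the carbonyl carbon, so it could not show that changing this single group, meta to a large group, is enough to produce a large rise. Nothing available gives a reason for this rise.

The compounds shown leave open whether a nitrile or a chlorine at this place would keep the number high, and whether an amine or a carboxylic acid there would bring it back down. They also leave open whether trifluoromethyl would give a similar number on another carbon of the same ring.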